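The source may report more compounds than this note shows. Statements on the series, on what has been measured and on what is new or still open speak of the compounds shown alone.

Compound 2, `CN(CCNCc1cn(Cc2ccc(Br)cc2)nn1)CCNc1ccnc2cc(Cl)ccc12`, gives 12000 nM in a functional assay on NCI-H460 cells (Homo sapiens) for antiproliferative activity, read by sulforhodamine B assay, with a stated time of 72 h (on this read-out higher numbers stand for weaker inhibition and lower numbers for stronger inhibition), the lowest of the two numbers in hand. Compound 1, `C#CCNCCN(C)CCNc1ccnc2cc(Cl)ccc12`, gives 69000 nM in this assay, a result that lies beyond the scatter from that of compound 2. Compound 3, `CN(CCNCc1cn(CCCn2nn[nH]c2=O)nn1)CCNc1ccnc2cc(Cl)ccc12`, has not yet been measured. It differs from compound 2 in one place: a group of 8 heavy atoms (3 carbon, 4 nitrogen, 1 oxygen; one five-membered aromatic ring with 4 hetero atoms) in place of a group of 7 heavy atoms (6 carbon, 1 bromine; one six-membered aromatic ring of carbon only), on a saturated chain carbon bound to an aromatic nitrogen. Within the data shown here, no step between measured compounds covers a change of this kind, so the expected size rests only on the two values known; a modest loss is expected, with the step of a 2.1-fold higher number from compound 2 to compound 3 (0.32 log units; beyond the scatter) in this assay. Compound 3 is thus estimated at 25000 nM, within a range from 8000 nM to 80000 nM.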

Compound 3, half-maximal inhibitory concentration: > 200000 nM
Compound 3 gave a limit, no number (the forecaster's own chance of this, stated with the estimate: 10%); middle value at least 8.0-fold (0.90 log units) from the limit.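

In this assay, the group on the saturated chain carbon bound to an aromatic nitrogen proves decisive: replacing 4-bromophenyl with the chain carrying a five-membered aromatic ring with 4 hetero atoms gives an at least 16-fold higher number from compound 2 to compound 3 (1.22 log units; beyond the scatter). For compound 3 the result is a limit and not a number: the limit of > 200000 nM in this assay, at which 1 of the 3 values shown sits. Two groups of nearly equal heavy-atom count are therefore not interchangeable at this place. The compounds shown do not separate the contribution of the entering ring from that of its chain. Nor do they show how a plain phenyl, an amine or a carboxylic acid would read here.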